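Swapping one hydroxyphenyl arm on a tris-aryl pyridine core

The source may hold more compounds than are shown below. What is called first, only, known or untested is meant among the compounds shown, and "the series" means these compounds.

Compound 1, with structure `Oc1ccc(-c2cc(-c3ccc(O)cc3)nc(-c3ccc(O)cc3)c2)cc1`, is tested in a functional assay on DU-145 cells (Homo sapiens) for cytotoxicity, read by CCK-8 assay, with a stated time of 4 days (on this read-out lower numbers stand for stronger inhibition and higher numbers for weaker inhibition), where compound 1 gives 3160 nM. Within the data shown here, that is the only plain number in this set; compound 1 therefore stands alone as the single measured value, with no second number beside it for comparison. Compound 2, with structure `Oc1cccc(-c2cc(-c3cccc(O)c3)nc(-c3ccccc3O)c2)c1`, gives in this assay only a limit, > 50000 nM, and the limit of > 50000 nM in this assay, at which 1 of the 2 values shown sits, marks it as such. Compound 3, with structure `Oc1ccc(-c2cc(-c3ccccc3O)cc(-c3ccc(O)cc3)n2)cc1`, is not yet measured. It differs from compound 1 by 2-hydroxyphenyl in place of 4-hydroxyphenyl on an aromatic carbon, so the same atoms are present but one arm of the shared core is rearranged. Among the measured compounds shown here, no measured pair in this set isolates that single change, so the expected step cannot be read from a neighbour. Compound 3 is expected to land at 8000 nM, within 2500 nM to 30000 nM, an estimated step from compound 1 to compound 3 of a 2.5-fold higher number from compound 1 to compound 3 (0.40 log units; beyond the scatter) toward weaker inhibition.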

Compound 3, half-maximal inhibitory concentration: 980 nM
The estimate for compound 3 lay 8.2-fold (0.91 log units) above the measured number; measured number outside the range, below it.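

The arm opposite the ring nitrogen turns out to be sensitive to where its hydroxyl sits: with the same atoms present, 2-hydroxyphenyl in place of 4-hydroxyphenyl gives in this assay a 3.2-fold lower number from compound 1 to compound 3 (0.51 log units; beyond the scatter) and so moves toward stronger inhibition. Compound 1 alone could not show this, since a single number says nothing about how a change at this position moves the read-out. Nothing measured here explains why the rearranged arm gives the lower number.

Among these compounds, compound 2 gives only a limit of > 50000 nM and differs from compound 1 in more than one place, so no step to it can be read. Still open, as far as these compounds go, is whether a methoxy group or an amine in place of the hydroxyl on this arm would keep the lower number, and whether the same shift on the two remaining 4-hydroxyphenyl arms would act alike.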